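Acyl Pyrrolidines on a Fused Core: Expecting Compound 4

A few compounds are considered here, and "the series" means these few. Any claim that something is new, unique, unknown or untested is made for them only; others in the source may bear on it.

Of the compounds shown here, three sharing one core have been measured in a functional assay on HCC827 cells (Homo sapiens) for antiproliferative activity, read by MTT assay, with a stated time of 72 h; on this read-out higher numbers stand for weaker inhibition and lower numbers for stronger inhibition. Compound 1 `CN1CCN(c2ccc(Nc3ncc4nc(Nc5ccc(F)cc5)n([C@@H]5CCCNC5)c4n3)cc2)CC1` gives 120 nM and stands second highest of the three numbers. Compound 2 `CN1CCN(c2ccc(Nc3ncc4nc(Nc5ccccc5)n([C@@H]5CCN(S(=O)(=O)C6CC6)C5)c4n3)cc2)CC1`, which carries a 1-(cyclopropylsulfonyl)pyrrolidin-3-yl group on the aromatic nitrogen, gives 0.88 nM. Among the measured compounds shown here, compound 3 `CC(=O)N1CC[C@H](n2c(Nc3ccccc3)nc3cnc(Nc4ccc(N5CCN(C)CC5)cc4)nc32)C1`, with a 1-acetylpyrrolidin-3-yl group in that place, gives 260 nM; the two values of compound 1 and compound 3 lie beyond the scatter of each other, though no single-point step joins them.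

The unmeasured compound 4 `CN1CCN(c2ccc(Nc3ncc4nc(Nc5ccc(F)cc5)n([C@H]5CCN(C(=O)CO)C5)c4n3)cc2)CC1` differs from compound 1 in one place: 1-((hydroxymethyl)carbonyl)pyrrolidin-3-yl in place of piperidin-3-yl on an aromatic nitrogen. For the measured compounds named here, the only measured step that bears on this change is a 300-fold higher number from compound 2 to compound 3 (2.47 log units; beyond the scatter), which shows that an acylated pyrrolidine on this nitrogen sits far above the sulfonylated one in this assay. Compound 4 carries an acyl pyrrolidine of the same kind as compound 3, while compound 1 carries the unsubstituted piperidine, and compound 3 itself is close to compound 1. He therefore expects no step beyond the scatter, a 1.3-fold higher number from compound 1 to compound 4 (0.10 log units; within the scatter), from compound 1 to compound 4. His estimate for compound 4 in this assay is 150 nM, with a range from 30 nM to 700 nM.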

Compound 4, half-maximal inhibitory concentration: 380 nM
Beside the measured number, compound 4's estimate is 2.5-fold (0.40 log units) below it; measured number inside the range.
By their numbers in this assay, from the lowest: compound 2; then compound 1; then compounds 3 and 4 (each within the scatter of the next).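

In this assay, among the compounds shown here, the new result supplies the first step at this aromatic nitrogen that starts from a ring with nothing on its ring nitrogen: 1-((hydroxymethyl)carbonyl)pyrrolidin-3-yl in place of piperidin-3-yl gives a 3.2-fold higher number from compound 1 to compound 4 (0.50 log units; beyond the scatter) and so a modest loss that still lies beyond the scatter. For the compounds shown here, it is also the first step at this position on a compound whose neighbouring ring atom bears a (4-fluorophenyl)amino group, and it is much smaller than the large 300-fold higher number from compound 2 to compound 3 (2.47 log units; beyond the scatter) that separates the acetyl from the cyclopropylsulfonyl group on a pyrrolidine. Nothing available here accounts for the size of either step.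

The new step changes the ring from six-membered to five-membered and adds the acyl group at once, so the compounds shown cannot divide it between the two changes, and a plain pyrrolidin-3-yl on the compound 1 core would be needed to do so. They also leave open how a 1-(aminoacetyl)pyrrolidin-3-yl group or a carboxylic acid at the end of the acyl chain would read here, and whether the 1-(cyclopropylsulfonyl)pyrrolidin-3-yl group would hold its low number alongside the (4-fluorophenyl)amino group.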